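The compounds below may be only part of what the source reports. "The series", "measured", "known", "first", "only" and "open" are said of these compounds alone.

Compound 1 `O=C(OCc1ccc(Cl)c(Cl)c1)N(c1ccccc1)C1CN2CCC1CC2`: 60 nM
Compound 2 `COc1ccc(CCCOC(=O)N(c2ccccc2)C2CN3CCC2CC3)cc1OC`: 1610 nM
Compound 3 `O=C(OCCCc1ccc(F)c(F)c1)N(c1ccccc1)C1CN2CCC1CC2`: 100 nM

In an assay on CHO cells for displacement of a labelled ligand from muscarinic acetylcholine receptor M5 (Homo sapiens), read by scintillation counting, with a stated time of 2 h (on this read-out lower numbers stand for stronger inhibition and higher numbers for weaker inhibition), compound 1 gives the lowest of the three numbers, though compound 3 lies within the usual scatter of it, while compound 2 lies well beyond. Compound 4 `COc1ccc(COC(=O)N(c2ccccc2)C2CN3CCC2CC3)cc1` differs from compound 1 by 4-methoxyphenyl in place of 3,4-dichlorophenyl on a saturated chain carbon bound to an oxygen next to a carbonyl group. Within the data shown here, the one measured step that bears on such a change is a 16-fold lower number from compound 2 to compound 3 (1.21 log units; beyond the scatter), in which halogens on the ring in place of methoxy groups brought a much lower number. Read in the opposite direction, that step points to a higher number for compound 4, although the chain length and the pattern of ring substitution differ from the measured pair, so the size is uncertain. Compound 4 is therefore expected to give 400 nM, with a range from 120 nM to 1500 nM, an expected step of a 6.7-fold higher number from compound 1 to compound 4 (0.82 log units; beyond the scatter).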

Compound 4, inhibition constant: 470 nM
Beside the measured number, compound 4's estimate is 1.2-fold (0.07 log units) below it; the range from low to high includes it.
By their numbers in this assay, from the lowest: compounds 1 and 3 (each within the scatter of the next); then compound 4; then compound 2.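

In this assay, the step with 4-methoxyphenyl in place of 3,4-dichlorophenyl on a saturated chain carbon bound to an oxygen next to a carbonyl group is a 7.8-fold higher number from compound 1 to compound 4 (0.89 log units; beyond the scatter). This lies in the same direction as the earlier step between compound 2 and compound 3. The methoxy-bearing ring thus gives the higher number on this shorter chain too, although this step is modest. Nothing available explains this change.

The compounds shown leave open how a plain phenyl or a ring bearing a single chlorine would compare at this place. They also leave open whether a ring with a nitrile would follow the same direction.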